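The compounds below may be only part of what the source reports. "The series", "measured", "known", "first", "only" and "open" are said of these compounds alone.

Working notes on the series. Compound 1 `CCCCC#Cc1nc(NCc2cccc(Cl)c2)c2ncn([C@@H]3SC[C@@H](O)[C@H]3O)c2n1` and compound 2 `CCCCC#Cc1nc(N)c2ncn([C@@H]3OC[C@@H](O)[C@H]3O)c2n1` have been measured in an assay on CHO cells for displacement of a labelled ligand from adenosine receptor A3 (Homo sapiens), with a stated time of 60 min; a higher number here means a weaker inhibitor, a lower number a stronger inhibitor. In this assay compound 1 gives 24 nM and compound 2 gives 138 nM. Among the compounds with values here, compound 2 therefore stands at the higher of the two numbers, with compound 1 a good way below it, beyond the scatter; the two structures differ in more than one place, so no single step connects them and only the two values themselves can be compared.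

Compound 3 `CCCCC#Cc1nc(NCc2cccc(Br)c2)c2ncn([C@@H]3OC[C@@H](O)[C@H]3O)c2n1` has not yet been measured in this assay. It differs from compound 2 in one place: 3-bromobenzyl in place of hydrogen on a nitrogen on an aromatic ring. Within the data shown here, no measured step of this kind is available. Among the measured compounds shown here, the only guide is that compound 1, the one member carrying a substituted benzyl on that nitrogen, gives 24 nM in this assay, well under the number of compound 2; on that basis a move downward beyond the scatter is expected from compound 2 to compound 3, the estimated step being a 5.5-fold lower number from compound 2 to compound 3 (0.74 log units; beyond the scatter). For compound 3 the expected inhibition constant in this assay is 25 nM, with a range from 6 nM to 100 nM.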

Compound 3, inhibition constant: 67 nM
The estimate for compound 3 lay 2.7-fold (0.43 log units) below the measured number; the measured number falls inside the stated range.
By their numbers in this assay, from the lowest: compound 1; then compound 3; then compound 2.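

In this assay, within the data shown here, the change from amino to (3-bromobenzyl)amino gives a 2.1-fold lower number from compound 2 to compound 3 (0.31 log units; beyond the scatter) and so supplies the first step that can be read at this position, where the earlier compounds offered only two values separated by more than one difference. The nitrogen therefore carries a group of 8 heavy atoms, with one six-membered aromatic ring of carbon only, and the number still moves down rather than up, although the step is modest and lies only narrowly beyond the scatter. No measured property of these compounds bears on the size of this step.

As far as these compounds go, with a single step at this position, it remains open whether an unsubstituted benzyl, or a 3-chlorobenzyl on the core of compound 3, would give a number different from that of compound 3. Also open, from the compounds shown here alone, is whether the downward move would hold for a phenylethyl or a cyclopentyl on the same nitrogen, or whether it belongs to the 3-bromobenzyl alone.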